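A few compounds are considered here, and "the series" means these few. Any claim that something is new, unique, unknown or untested is made for them only; others in the source may bear on it.

Measured compounds:
- compound 1, `Cc1ccc2oc(SCC(=O)Nc3ccc(-c4nc(-c5ccccc5)c(-c5ccccc5)n4C)cc3)nc2c1`: 15.5%
- compound 2, `Cc1nnc(SCC(=O)Nc2ccc(-c3nc(-c4ccccc4)c(-c4ccccc4)n3C)cc2)s1`: 39.9%

Within the data shown here, in a functional assay on HT-29 cells (Homo sapiens) for cytotoxicity, read by MTT assay, with a stated time of 24 h, tested at 1.6 ug/mL (on this read-out lower numbers stand for a weaker effect and higher numbers for a stronger effect at the one concentration tested), compound 2 holds the highest of the two numbers; the only neighbour is compound 1, and the step from compound 1 to compound 2 is a number 24.4 percentage points higher from compound 1 to compound 2 (beyond the scatter), which exchanged one heteroaryl group on the sulfur for another.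

Compound 3, `Cn1ccnc1SCC(=O)Nc1ccc(-c2nc(-c3ccccc3)c(-c3ccccc3)n2C)cc1`, has not been measured in this assay. It differs from compound 2 in one place: 1-methyl-1H-imidazol-2-yl in place of 5-methyl-1,3,4-thiadiazol-2-yl on a sulfur

Among the measured compounds shown here, no measured step exchanges the 5-methyl-1,3,4-thiadiazol-2-yl group for the 1-methyl-1H-imidazol-2-yl group. For the measured compounds named here, the one step available, a number 24.4 percentage points higher from compound 1 to compound 2 (beyond the scatter), shows that exchanging the group on this sulfur can move the read-out by a modest amount in either direction. The step from compound 2 to compound 3 is therefore expected to be a number 9.9 percentage points lower from compound 2 to compound 3 (within the scatter), with a wide range. Compound 3 is estimated to give 30%, between 10% and 55%.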

Compound 3, a percentage reported as activity, at one concentration (the size of the read-out at that concentration, not a potency): 23.8%
Estimate against measurement, compound 3: 6.2 percentage points above; measured number inside the range.
By their numbers in this assay, from the lowest: compounds 1 and 3 (each within the scatter of the next); then compound 2.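

In this assay the exchange of 5-methyl-1,3,4-thiadiazol-2-yl for 1-methyl-1H-imidazol-2-yl on the sulfur gives a number 16.1 percentage points lower from compound 2 to compound 3 (beyond the scatter) and shows that a second group also falls short of the thiadiazole compound. The two groups carry the same heavy-atom count, so that count alone does not set the read-out for this pair, while a number 8.3 percentage points higher from compound 1 to compound 3 (within the scatter) leaves 1-methyl-1H-imidazol-2-yl and 5-methyl-1,3-benzoxazol-2-yl unseparated. Nothing available gives a reason for the drop from the thiadiazole compound.

Still open, as far as these compounds go, is whether the 5-methyl-1,3,4-thiadiazol-2-yl result holds when an amine or a longer chain takes the place of its methyl. Also open is how a carboxylic acid on the same ring would read, and the single tested concentration gives no potency for any of these compounds.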